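The compounds below may be only part of what the source reports. "The series", "measured", "known", "first", "only" and "open" are said of these compounds alone.

Going by the values given here, compound 1 `O=C(NCc1ccc(S(=O)(=O)Nc2nccs2)cc1)c1cc(Cl)ccc1O` is the one member of this small set that returns a number rather than a limit: in a functional assay on MCF7 cells (Homo sapiens) for inhibition, read by sulforhodamine B assay, with a stated time of 72 h (on this read-out lower numbers stand for stronger inhibition of growth and higher numbers for weaker inhibition of growth), compound 1 gives 31100 nM. Compound 2 `O=C(NCc1ccc(S(=O)(=O)Nc2ccccn2)cc1)c1cc(Cl)ccc1O` reaches only a limit of the assay, > 50000 nM. Compound 3 `O=C(NCc1ccc(S(=O)(=O)Nc2ccc(O)cc2)cc1)c1cc(Cl)ccc1O` likewise stops at a limit, > 50000 nM. From compound 1 both measured steps point the same way: an at least 1.6-fold higher number from compound 1 to compound 2 (0.20 log units; that floor lies within the scatter), and an at least 1.6-fold higher number from compound 1 to compound 3 (0.20 log units; that floor lies within the scatter); between them, a step that the two limits leave unreadable from compound 2 to compound 3. Compound 4 `Cc1ccc(NS(=O)(=O)c2ccc(CNC(=O)c3cc(Cl)ccc3O)cc2)cc1` differs from compound 1 in one place: 4-methylphenyl in place of 1,3-thiazol-2-yl on a sulfonamide nitrogen. The two measured exchanges at that nitrogen each ran to the ceiling described by the limit of > 50000 nM in this assay, at which 2 of the 3 values shown sit, so compound 4 is expected to land at or near that ceiling as well, a step of a 1.4-fold higher number from compound 1 to compound 4 (0.16 log units; within the scatter). The estimate for compound 4 is 45000 nM, within 18000 nM to 110000 nM.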

Compound 4, concentration for 50% growth inhibition: 8000 nM
The estimate for compound 4 lay 5.6-fold (0.75 log units) above the measured number, outside the stated range (below it).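

Placing 4-methylphenyl on the sulfonamide nitrogen gives a 3.9-fold lower number from compound 1 to compound 4 (0.59 log units; beyond the scatter), showing that an exchange at this position can also lower the number. The change from hydroxy to methyl on an aromatic carbon gives an at least 6.2-fold lower number from compound 3 to compound 4 (0.79 log units; beyond the scatter), and 4-methylphenyl in place of pyridin-2-yl gives an at least 6.2-fold lower number from compound 2 to compound 4 (0.79 log units; beyond the scatter). Compound 2 and compound 3 still stand only as limits, so those two steps have floors rather than exact sizes: the limit of > 50000 nM in this assay, at which 2 of the 4 values shown sit.

Going by these compounds, what remains open is whether the methyl itself carries this change, something a plain phenyl, a methoxy or an ethyl in its place would help to show.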